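A few compounds are considered here, and "the series" means these few. Any claim that something is new, unique, unknown or untested is made for them only; others in the source may bear on it.

Working notes on the series.

Compound 1 `COC(=O)[C@@]1(C)CC[C@@H]2C3=C1CC[C@@H](C)[C@]3(C)C[C@@H]1c3cc(C)ccc3N[C@H]21` carries a methyl group on its aromatic ring, and in a functional assay on A549 cells (Homo sapiens) for inhibition, read by sulforhodamine B assay, with a stated time of 48 h (a lower number here means a stronger inhibitor of growth, a higher number a weaker inhibitor of growth), compound 1 gives 27000 nM. Compound 2 `COC(=O)[C@@]1(C)CC[C@@H]2C3=C1CC[C@@H](C)[C@]3(C)C[C@@H]1c3cc(Br)ccc3N[C@H]21` is the same core with bromo in place of that methyl, and in this assay compound 2 gives 40000 nM. The change from compound 1 to compound 2 is bromo in place of methyl on an aromatic carbon, and it made a step of a 1.5-fold higher number from compound 1 to compound 2 (0.17 log units; within the scatter).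

Compound 3 `COC(=O)[C@@]1(C)CC[C@@H]2C3=C1CC[C@@H](C)[C@]3(C)C[C@@H]1c3cccc(C)c3N[C@H]21` has the same atoms as compound 1, joined differently; the difference between the two cores is not broken down here. In this assay compound 3 gives 30000 nM, a number that lies within the scatter of both compound 1 and compound 2, so no order among the three can be read from these values.

Compound 4 `COC(=O)[C@@]1(C)CC[C@@H]2C3=C1CC[C@@H](C)[C@]3(C)C[C@@H]1c3cccc(Br)c3N[C@H]21` has not yet been measured in this assay. Its relation to compound 3 is bromo in place of methyl on an aromatic carbon. Among the measured compounds shown here, this is the same kind of change as the one from compound 1 to compound 2, but not the same: in compound 3 the exchanged group sits ortho to a fused ring and meta to a fused ring, whereas in compound 1 it sits meta to a fused ring and para to a fused ring.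

For the measured compounds named here, for compound 4 a step of a 1.3-fold higher number from compound 3 to compound 4 (0.12 log units; within the scatter) is expected, placed beside the measured step from compound 1 to compound 2, because that step was a 1.5-fold higher number from compound 1 to compound 2 (0.17 log units; within the scatter) and a change of the same kind on a similar core is the only guide available. The estimate for compound 4 in this assay is therefore 40000 nM, with a range from 20000 nM to 80000 nM.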

Compound 4, concentration for 50% growth inhibition: 42000 nM
Compound 4: middle estimate off by 1.1-fold (0.02 log units), on the low side; the range from low to high includes it.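

In this assay, among the compounds shown here, bromo in place of methyl on an aromatic carbon gives a 1.4-fold higher number from compound 3 to compound 4 (0.15 log units; within the scatter), so on this core the exchange leaves no step that can be told from repeat measurement. Set beside the earlier step, the same exchange on the core of compound 1 gives a matching result: the same change on two cores in this assay, a 1.5-fold higher number (0.17 log units; within the scatter) from compound 1 to compound 2 and a 1.4-fold higher number (0.15 log units; within the scatter) from compound 3 to compound 4, 1.1-fold (0.02 log units) apart, within the scatter of two such steps. This shows that, for these two pairs, with the exchanged group at two different places on the aromatic ring, the exchange of methyl for bromo carries over as a small step in both, but it does not show a real difference between bromo and methyl, since neither step stands clear of the scatter, and two such steps cannot establish a rule for any other core or any other pair of groups.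

The compounds shown hold the methyl ester constant and vary only methyl and bromo at two places on the aromatic ring, so the reach of the aromatic position beyond these two groups stays open. Whether an amine or a longer chain on that ring, or a carboxylic acid in place of the methyl ester, would move the number beyond the scatter remains unanswered.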